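The source may hold more compounds than are shown below. What is called first, only, known or untested is meant among the compounds shown, and "the series" means these compounds.

Compound 1 `CC(=O)N1CCC(Sc2c[nH]c3ccc(Cl)cc23)CC1` and compound 2 `CC(=O)N1CCC(Sc2c[nH]c3ccc(Br)cc23)CC1` share one core, while compound 3 `CN1CCC(Sc2cn(C)c3ccc(Cl)cc23)CC1` and compound 4 `CN1CCC(Sc2cn(C)c3ccc(Br)cc23)CC1` share another; the difference between the two cores is not broken down here. In a functional assay on the whole organism with Mus musculus as the target, in the hot plate test (on this read-out higher numbers stand for an effect only at larger amounts of compound and lower numbers for an effect already at smaller amounts), compound 1 gives 3.8 mg/kg and compound 2 gives 2.8 mg/kg. The change that separates them, (bromo in place of chloro on an aromatic carbon), made a 1.4-fold lower number from compound 1 to compound 2 (0.13 log units; within the scatter). In this assay compound 3 gives 9.3 mg/kg. Compound 4 carries the same change on the other core, (bromo in place of chloro on an aromatic carbon), placed exactly as before. Because the earlier step was a 1.4-fold lower number from compound 1 to compound 2 (0.13 log units; within the scatter), the step from compound 3 to compound 4 is expected to be small as well, a 1.3-fold lower number from compound 3 to compound 4 (0.12 log units; within the scatter). Compound 4 is therefore estimated to give 7 mg/kg in this assay, with a likely range from 3.5 mg/kg to 14 mg/kg, and only the measurement can say whether this holds.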

Compound 4, dose for half-maximal effect: 8.6 mg/kg
Beside the measured number, compound 4's estimate is 1.2-fold (0.09 log units) below it; the range from low to high includes it.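

On the core of compound 3, bromo in place of chloro gives a 1.1-fold lower number from compound 3 to compound 4 (0.03 log units; within the scatter) in this assay. Set beside the step on the core of compound 1, the two steps agree: the same change on two cores in this assay, a 1.4-fold lower number (0.13 log units; within the scatter) from compound 1 to compound 2 and a 1.1-fold lower number (0.03 log units; within the scatter) from compound 3 to compound 4, 1.3-fold (0.10 log units) apart, within the scatter of two such steps

So between these two cores, this swap carries over as a step too small to read above the scatter, but with only two pairs this does not show that it would behave the same way on any other core or in any other test.

Chloro and bromo are the only groups shown at this aromatic carbon, so what fluoro, methoxy or a nitrile would do there remains open. Which part of the difference between the two cores matters also remains open.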